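The source may report more compounds than this note shows. Statements on the series, on what has been measured and on what is new or still open speak of the compounds shown alone.

In a functional assay on MDA-MB-231 cells (Homo sapiens) for inhibition, read by MTT assay, with a stated time of 72 h (a higher number here means a weaker inhibitor, a lower number a stronger inhibitor), compound 1 (`COc1ccccc1-c1csc2cnc(Nc3ccc(NC(=O)[C@H]4CCCNC4)cc3)nc12`) gives 440 nM and compound 2 (`COc1ccccc1-c1csc2cnc(Nc3ccc(C(=O)NC4CCNCC4)cc3C(F)(F)F)nc12`) gives 2750 nM as the higher of the two numbers, a gap beyond the usual scatter. Compound 3 (`COc1ccccc1-c1csc2cnc(Nc3ccc(C(=O)NC4CCNCC4)cc3)nc12`) differs from compound 2 by hydrogen in place of trifluoromethyl on an aromatic carbon in one place: hydrogen in place of trifluoromethyl on an aromatic carbon. Within the data shown here, no measured pair shows this change alone, so the expectation is tentative. A moderate fall in the number is expected in this assay with an estimated 3.1-fold lower number from compound 2 to compound 3 (0.49 log units; beyond the scatter) that lies somewhat beyond the scatter. Compound 3 is estimated at 900 nM with 280 nM to 2600 nM as the expected range.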

Compound 3, half-maximal inhibitory concentration: 110 nM
For compound 3 the middle estimate is 8.2-fold (0.91 log units) above the measured one; the whole stated range lies above it.
By their numbers in this assay, from the lowest: compound 3; then compound 1; then compound 2.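

In this assay the trifluoromethyl group on this aromatic carbon, meta to the (piperidin-4-yl)carbamoyl group, carries a large penalty: hydrogen in its place gives a 25-fold lower number from compound 2 to compound 3 (1.40 log units; beyond the scatter) on an otherwise unchanged structure. On the shared core, (piperidin-4-yl)carbamoyl in place of ((piperidin-3-yl)carbonyl)amino gives a more modest a 4.0-fold lower number from compound 1 to compound 3 (0.60 log units; beyond the scatter) as the second step. Going by these compounds, whether a fluorine, a chlorine or a methyl group on this carbon would stay close to hydrogen remains open, as does the effect of a methoxy group there. No measured evidence here accounts for either step.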